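Swapping Chloro for Trifluoromethyl: What the Earlier Step Suggests

A few compounds are considered here, and "the series" means these few. Any claim that something is new, unique, unknown or untested is made for them only; others in the source may bear on it.

The measured compounds:
Compound 1, `O=C(/C=C\Nc1ccc(Cl)cc1)c1cn(-c2ccccc2)nc1-c1ccc(F)cc1`: in a functional assay on A549 cells (Homo sapiens) for antiproliferative activity, read by MTT assay, with a stated time of 48 h (on this read-out lower numbers stand for stronger inhibition and higher numbers for weaker inhibition), compound 1 gives 6700 nM.
Compound 2, `O=C(/C=C\Nc1ccc(C(F)(F)F)cc1)c1cn(-c2ccccc2)nc1-c1ccc(F)cc1`: in this assay compound 2 gives only a limit of the assay, > 50000 nM.
Compound 3, `COc1ccc(-c2nn(-c3ccccc3)cc2C(=O)/C=C\Nc2ccc(Cl)cc2)cc1`: in this assay compound 3 gives 2970 nM.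

Compound 1 and compound 3 share the same core and differ only in one group: methoxy in place of fluoro on an aromatic carbon. That change gave a 2.3-fold lower number from compound 1 to compound 3 (0.35 log units; beyond the scatter), so compound 3 stands as the lowest of the two numbers that were actually read.

The change from compound 1 to compound 2 is a different one: trifluoromethyl in place of chloro on an aromatic carbon. It gave an at least 7.4-fold higher number from compound 1 to compound 2 (0.87 log units; beyond the scatter). As far as these compounds go, for compound 2 the assay reports only a limit, (the limit of > 50000 nM in this assay, at which 1 of the 3 values shown sits), so the true size of that step is unknown beyond its floor.

Compound 4, `COc1ccc(-c2nn(-c3ccccc3)cc2C(=O)/C=C\Nc2ccc(C(F)(F)F)cc2)cc1`, has not yet been measured. It differs from compound 3 in exactly the same way that compound 2 differs from compound 1: trifluoromethyl in place of chloro on an aromatic carbon. The surroundings of the changed group read the same in both pairs, so this is the same change made on the core of compound 3 instead of the core of compound 1.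

From compound 3 to compound 4 the expected step is a 12-fold higher number from compound 3 to compound 4 (1.07 log units; beyond the scatter), and this expectation rests on the earlier step, an at least 7.4-fold higher number from compound 1 to compound 2 (0.87 log units; beyond the scatter). Compound 4 is therefore estimated at 35000 nM, with an expected range from 15000 nM to 90000 nM, and a real chance that the assay again returns only a limit.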

Compound 4, half-maximal inhibitory concentration: > 50000 nM
Compound 4 gave a limit, no number; the forecaster's own chance of this, stated with the estimate: 45%; at least 1.4-fold (0.15 log units) between middle value and limit.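

In this assay compound 4 gives > 50000 nM, which is a limit of the assay and not a number, and this limit is now reached by a second compound: the limit of > 50000 nM in this assay, at which 2 of the 4 values shown sit. Trifluoromethyl in place of chloro again pushes the number up, this time with an at least 16-fold higher number from compound 3 to compound 4 (1.22 log units; beyond the scatter), so the loss seen on the core of compound 1 also appears on the core of compound 3, though two pairs are all that show it. The direction of the change carries over, but its size does not come out as a firm figure, and the step between compound 2 and compound 4 cannot be read at all, since both ends are limits: the same change on two cores in this assay, an at least 7.4-fold higher number (0.87 log units; beyond the scatter) from compound 1 to compound 2 and an at least 16-fold higher number (1.22 log units; beyond the scatter) from compound 3 to compound 4; the limit leaves it open whether they differ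

As far as these compounds go, it stays open whether trifluoromethyl costs more on one core than on the other, as neither compound carrying it gives a true number. Also open is how other groups at the same place on the ring would behave on these two cores, such as a nitrile, an amine or a carboxylic acid, since among the groups shown there only chloro gives a readable number.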